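A few compounds are considered here, and "the series" means these few. Any claim that something is new, unique, unknown or untested is made for them only; others in the source may bear on it.

Measured compounds:
- compound 1 `COc1ccc(-c2nc(Nc3ccc(S(N)(=O)=O)cc3)n3c(=O)[nH]nc3c2C#N)cc1OC`, which in a functional assay on HeLa cells (Homo sapiens) for inhibition, read by sulforhodamine B assay, with a stated time of 48 h (on this read-out lower numbers stand for stronger inhibition and higher numbers for weaker inhibition), gives 47 nM
- compound 2 `COc1ccc(-c2nc(Nc3ccc(S(N)(=O)=O)cc3)nc(-n3nc(C)cc3C)c2C#N)cc1OC`, which in this assay gives 41 nM

Compound 2 gives the lower of the two numbers, but compound 1 sits within the usual scatter of it, so no real difference between them can be claimed. Compound 3 `COc1ccc(-c2nc(Nc3ccc(S(N)(=O)=O)cc3)nc(N3N=C(C)CC3=O)c2C#N)cc1OC` has not yet been measured in this assay. It differs from compound 2 in one place: a group of 7 heavy atoms (4 carbon, 2 nitrogen, 1 oxygen; one five-membered non-aromatic ring with 2 hetero atoms) in place of a group of 7 heavy atoms (5 carbon, 2 nitrogen; one five-membered aromatic ring with 2 hetero atoms), on an aromatic carbon. Going by the values given here, no measured pair shows what such a swap does, so any expectation rests only on how close compound 1 and compound 2 sit to each other. The change is expected to be a 2.0-fold higher number from compound 2 to compound 3 (0.29 log units; within the scatter), a small step, perhaps a slight weakening, but not clearly beyond the scatter. For compound 3 the estimated value in this assay is 80 nM, with a likely range from 25 nM to 300 nM.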

Compound 3, half-maximal inhibitory concentration: 46 nM
Beside the measured number, compound 3's estimate is 1.7-fold (0.24 log units) above it, and the stated range covers the measured number.
By their numbers in this assay, from the lowest: compounds 2, 3 and 1 (each within the scatter of the next).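

Going by these compounds alone, this is the first pair of compounds that differ only at this position, the aromatic carbon ortho to a cyano group. In this assay, putting a five-membered non-aromatic ring with one oxygen in place of the 3,5-dimethyl-1H-pyrazol-1-yl group gives a 1.1-fold higher number from compound 2 to compound 3 (0.05 log units; within the scatter) and so shows that, in this pair, an aromatic ring at this position is not needed for a number in this range. Nothing measured here explains why the two groups read alike.

Both groups shown are five-membered rings, so it remains open whether a simple amine, a morpholine ring or an open carbon chain at this position would read the same. On these data alone, whether this swap would read alike on a different core also stays unknown.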